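Swapping the Ring on the Amide Nitrogen of Compound 1

The source may report more compounds than this note shows. Statements on the series, on what has been measured and on what is new or still open speak of the compounds shown alone.

Compound 1 `O=C1c2cc(COc3ccccc3)nn2CCN1c1ccc(F)c(F)c1` was tested in a functional assay on HEK293 cells for positive allosteric modulation of metabotropic glutamate receptor 5 (Homo sapiens), read by calcium flux (on this read-out higher numbers stand for larger maximal responses and lower numbers for smaller maximal responses), where compound 1 gives 81%. Its closest neighbour among the measured compounds is compound 2 `Cc1ccc(N2CCn3nc(COc4ccccc4)cc3C2=O)nc1`, which in this assay gives 76%; the step of a number 5 percentage points lower from compound 1 to compound 2 (within the scatter) lies within the usual scatter, so the two compounds cannot be told apart on this read-out. Compound 3 `COc1ccc(N2CCn3nc(COc4ccccc4)cc3C2=O)nc1` has not yet been measured. It differs from compound 1 at one place: 5-methoxypyridin-2-yl in place of 3,4-difluorophenyl on an amide-type nitrogen in a ring. Going by the values given here, the only measured step that bears on this change is the one in which 5-methylpyridin-2-yl replaced 3,4-difluorophenyl on the same amide-type nitrogen in a ring, and that gave a number 5 percentage points lower from compound 1 to compound 2 (within the scatter). For compound 3 the change is expected to bring a number 4 percentage points lower from compound 1 to compound 3 (within the scatter), nothing beyond the scatter. Compound 3 is therefore estimated to reach 77% in this assay, within a range from 62% to 92%.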

Compound 3, largest response reached (Emax), in percent of the reference or control that the assay uses: 74%
Compound 3: middle estimate off by 3 percentage points, on the high side, and the stated range covers the measured number.
By their numbers in this assay, from the lowest: compounds 3, 2 and 1 (each within the scatter of the next).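

Replacing 3,4-difluorophenyl with 5-methoxypyridin-2-yl on the amide-type nitrogen gives, in this assay, a number 7 percentage points lower from compound 1 to compound 3 (within the scatter), so a second substituted pyridine at this position keeps the maximal response in the same range as compound 1. Methoxy in place of methyl on an aromatic carbon of that pyridine gives a number 2 percentage points lower from compound 2 to compound 3 (within the scatter), and the 5-methoxypyridin-2-yl group's 2 hydrogen-bond acceptors, against 0 for 3,4-difluorophenyl, bring no step beyond the scatter. No measurement shown here offers an explanation for these results.

Whether a saturated ring such as piperidine on the same nitrogen would hold the response is open. So is the outcome of placing an amine, a carboxylic acid or a longer alkoxy chain on the pyridine.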